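Replacing the aminoalkyl side chain with a triazolyl diol

The source may hold more compounds than are shown below. What is called first, only, known or untested is meant among the compounds shown, and "the series" means these compounds.

Measured in a functional assay on A549 cells (Homo sapiens) for cytotoxicity, read by MTT assay, with a stated time of 72 h; a lower number here means a stronger inhibitor, a higher number a weaker inhibitor:
compound 1 `CN1CCN(CCCCCn2c3c(c4ccccc42)C(=O)c2c[n+]([O-])c4ccccc4c2C3=O)CC1` gives 870 nM
compound 2 `CC1(C)OC[C@@H](Cn2cc(Cn3c4c(c5ccccc53)C(=O)c3c[n+]([O-])c5ccccc5c3C4=O)nn2)O1` gives 4700 nM
compound 3 `CN1CCN(CCCn2c3c(c4ccccc42)C(=O)c2c[n+]([O-])c4ccccc4c2C3=O)CC1` gives 140 nM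

Compound 1 stands second highest of the three numbers, between compound 3 and compound 2. Going by the values given here, the only measured step, a 6.2-fold lower number from compound 1 to compound 3 (0.79 log units; beyond the scatter), concerns the chain and does not bear on the change to compound 4 `O=C1c2c[n+]([O-])c3ccccc3c2C(=O)c2c1c1ccccc1n2Cc1cn(C[C@H](O)CO)nn1`, which is 1-(2,3-dihydroxypropyl)-1H-1,2,3-triazol-4-yl in place of 4-(4-methylpiperazin-1-yl)butyl on a saturated chain carbon bound to an aromatic nitrogen. The nearest guide is compound 2, which also carries a triazole on the same position and gives the highest number shown, 4700 nM. Compound 4 is therefore expected to lie near compound 2 rather than compound 1, a step of a 3.4-fold higher number from compound 1 to compound 4 (0.54 log units; beyond the scatter) towards a higher number. The estimate for compound 4 is 3000 nM, with a range from 1000 nM to 10000 nM.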

Compound 4, half-maximal inhibitory concentration: 1030 nM
Compound 4: the middle estimate sits 2.9-fold (0.46 log units) above what was measured; the range from low to high includes it.
By their numbers in this assay, from the lowest: compound 3; then compounds 1 and 4 (each within the scatter of the next); then compound 2.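

In this assay the 1-(2,3-dihydroxypropyl)-1H-1,2,3-triazol-4-yl group on a saturated chain carbon bound to an aromatic nitrogen matches the 4-(4-methylpiperazin-1-yl)butyl group of compound 1 (a 1.2-fold higher number from compound 1 to compound 4 (0.07 log units; within the scatter)), so a methylpiperazine is not needed at this position for a number of that size, though compound 3 remains apart (a 7.4-fold higher number from compound 3 to compound 4 (0.87 log units; beyond the scatter)). At this position, 1,2-dihydroxyethyl in place of 2,2-dimethyl-1,3-dioxolan-4-yl also counts (a 4.6-fold lower number from compound 2 to compound 4 (0.66 log units; beyond the scatter)). No evidence on why these steps arise is available. Open, on these data alone, are a carboxylic acid or a primary amine in place of the diol, and a longer chain carrying the triazole.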